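The source may report more compounds than this note shows. Statements on the series, on what has been measured and on what is new or still open speak of the compounds shown alone.

Compound 1 `COc1ccc(-c2ccc(NC3=CC(=O)c4ncncc4C3=O)cc2)cc1`: 2300 nM
Compound 2 `NC(=O)c1ccc(NC2=CC(=O)c3ncncc3C2=O)cc1`: 6300 nM
Compound 3 `O=C1C(Nc2cccc(B(O)O)c2)=CC(=O)c2ncncc21`: 9000 nM

All three were measured in a functional assay on PANC-1 cells (Homo sapiens) for cytotoxicity, read by MTT assay, with a stated time of 72 h; a higher number here means a weaker inhibitor, a lower number a stronger inhibitor. Compound 2 stands second highest of the three numbers: compound 3 lies within the scatter of it, while compound 1 sits clearly lower, the step being a 2.7-fold higher number from compound 1 to compound 2 (0.44 log units; beyond the scatter). Compound 4 `O=C1C(Nc2ccc(CO)cc2)=CC(=O)c2ncncc21` is compound 2 with a single change: hydroxymethyl in place of carbamoyl on an aromatic carbon. Among the compounds with values here, no measured step swaps these two groups; the one measured step, a 2.7-fold higher number from compound 1 to compound 2 (0.44 log units; beyond the scatter), replaced a 4-methoxyphenyl and so does not bear directly on it. With nothing pointing either way, the expected step of a 1.1-fold lower number from compound 2 to compound 4 (0.06 log units; within the scatter) is none beyond the scatter. Compound 4 is therefore estimated at 5500 nM, with a range from 2500 nM to 13000 nM.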

Compound 4, half-maximal inhibitory concentration: 1000 nM
Compound 4: middle estimate off by 5.5-fold (0.74 log units), on the high side; measured number below the stated range.
By their numbers in this assay, from the lowest: compound 4; then compound 1; then compounds 2 and 3 (each within the scatter of the next).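

Two groups with the same counts, one hydrogen-bond donor and one hydrogen-bond acceptor, give clearly different numbers on this aromatic carbon: hydroxymethyl in place of carbamoyl produces (a 6.3-fold lower number from compound 2 to compound 4 (0.80 log units; beyond the scatter)), so those counts alone do not settle the outcome here. A large group is not needed for a low number either, since hydroxymethyl in place of 4-methoxyphenyl produces (a 2.3-fold lower number from compound 1 to compound 4 (0.36 log units; beyond the scatter)). Nothing measured here explains either step. Going by these compounds, whether an amine, a carboxylic acid or a longer chain ending in a hydroxyl would match hydroxymethyl remains open.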